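A few compounds are considered here, and "the series" means these few. Any claim that something is new, unique, unknown or untested is made for them only; others in the source may bear on it.

Two compounds have been measured so far in an ADME assay on Huh-7 cells (Homo sapiens) for cytotoxicity, read by XTT assay, with a stated time of 2 days (on this read-out lower numbers stand for higher toxicity in this test and higher numbers for lower toxicity in this test), and both results are limits:

Compound 1 `Cc1cn([C@H]2C[C@H](Br)[C@@H](CO)O2)c(=O)[nH]c1=O` gives > 100 ug/mL as a limit
Compound 2 `O=c1ccn([C@@H]2O[C@H](CO)[C@@H](Br)[C@@H]2O)c(=O)[nH]1` gives > 100 ug/mL as a limit

Compound 2 thus has no number of its own, and its place is simply the limit of > 100 ug/mL in this assay, at which 2 of the 2 values shown sit, and nothing finer. Compound 3 `Cc1cn([C@@H]2O[C@H](CO)[C@@H](Br)[C@@H]2O)c(=O)[nH]c1=O` has not yet been measured. It differs from compound 2 by methyl in place of hydrogen on an aromatic carbon, counted as methyl in place of hydrogen on an aromatic carbon and applied to the shared core. Within the data shown here, no measured pair shows this change alone, so any forecast is tentative. Compound 1 also carries that methyl and gives > 100 ug/mL as a limit. The expected change, a step that the limit leaves unreadable from compound 2 to compound 3 as estimated, is none beyond the usual scatter, in no favoured direction. Compound 3 is expected at 120 ug/mL with an estimated range from 60 ug/mL to 250 ug/mL in this assay. A limit rather than a number may well be expected for it too.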

Compound 3, half-maximal cytotoxic concentration: > 100 ug/mL
Compound 3 gave a limit, no number (the forecaster's own chance of this, stated with the estimate: 80%); the middle value does not contradict the limit.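

In this assay, among these compounds, compound 1, compound 2 and compound 3 all stand as limits, so no step among them can be read, and all three share one place: the limit of > 100 ug/mL in this assay, at which 3 of the 3 values shown sit. On these data alone, the concentration at which any of them would give a number, and what methyl in place of hydrogen on an aromatic carbon or hydroxy in place of hydrogen on a saturated ring carbon changes, stay open.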